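The source may hold more compounds than are shown below. What is called first, only, known or untested is meant among the compounds shown, and "the series" means these compounds.

Compound 3 `CC(=O)OC[C@H]1O[C@@H](n2cc(CN3C(=O)/C(=C\c4ccco4)c4ccccc43)nn2)[C@H](OC(C)=O)[C@@H](OC(C)=O)[C@@H]1OC(C)=O` is, in a functional assay on HeLa cells (Homo sapiens) for cytotoxicity, read by sulforhodamine B assay, with a stated time of 48 h (a higher number here means a weaker inhibitor, a lower number a stronger inhibitor), reported at > 100000 nM, a limit of the assay rather than a number. Compound 1 `CC(=O)OC[C@H]1O[C@@H](n2cc(CN3C(=O)/C(=C/c4ccc(C)cc4)c4ccccc43)nn2)[C@H](OC(C)=O)[C@@H](OC(C)=O)[C@@H]1OC(C)=O` gives 85600 nM in this assay. Compound 2 `CC(=O)OC[C@H]1O[C@@H](n2cc(CN3C(=O)/C(=C/c4ccc5ccccc5c4)c4ccccc43)nn2)[C@H](OC(C)=O)[C@@H](OC(C)=O)[C@@H]1OC(C)=O` sits at > 100000 nM, again a limit. Within the data shown here, the one measured step, an at least 1.1-fold higher number from compound 1 to compound 2 (0.06 log units; that floor lies within the scatter), is the only comparison available, and it rests on (the limit of > 100000 nM in this assay, at which 2 of the 3 values shown sit). Compound 4 `CC(=O)OC[C@H]1O[C@@H](n2cc(CN3C(=O)/C(=C/c4ccco4)c4ccccc43)nn2)[C@H](OC(C)=O)[C@@H](OC(C)=O)[C@@H]1OC(C)=O` differs from compound 3 in that (the two compounds have the same atoms and bonds and differ only in configuration as drawn: 1 of 6 stereo elements differ; a double bond is drawn Z in compound 3 and E in compound 4). Among the measured compounds shown here, no measured step changes a double-bond geometry, so nothing among the compounds speaks for a shift beyond the scatter. Compound 4 is therefore expected near 120000 nM, between 50000 nM and 300000 nM. The estimated step that the limit leaves unreadable from compound 3 to compound 4 is expected to stay within the scatter.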

Compound 4, half-maximal inhibitory concentration: 29900 nM
Compound 4: middle estimate off by 4.0-fold (0.60 log units), on the high side, outside the stated range (below it).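

In this assay, the geometry of the double bond at this position makes a difference, with an at least 3.3-fold lower number from compound 3 to compound 4 (0.52 log units; beyond the scatter), and nothing else changes: the fact that compounds 3 and 4 differ only in the configuration as drawn. With the double bond drawn E, furan-2-yl also separates from the other two groups, with a 2.9-fold lower number from compound 1 to compound 4 (0.46 log units; beyond the scatter) against 4-methylphenyl and an at least 3.3-fold lower number from compound 2 to compound 4 (0.52 log units; beyond the scatter) against naphthalen-2-yl. Two of these steps are floors, resting on a limit of the assay for compound 2 and compound 3: the limit of > 100000 nM in this assay, at which 2 of the 4 values shown sit.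

From the compounds shown here alone, whether the Z and E forms also differ with 4-methylphenyl or naphthalen-2-yl remains open. So does how an amine or a carboxylic acid in place of furan-2-yl would read.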